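The source may report more compounds than this note shows. Statements on the series, on what has been measured and on what is new or still open speak of the compounds shown alone.

Three compounds share one core and differ only in the groups carried on its aromatic ring. Compound 1 `CCCCCCCC/C=C/CCCCCCCC(=O)Nc1ccccc1CC` gives 1200 nM in an assay on microsomes from intestine for inhibition of acyl-CoA:cholesterol acyltransferase (Oryctolagus cuniculus); on this read-out lower numbers stand for stronger inhibition and higher numbers for weaker inhibition. Compound 2 `CCCCCCCC/C=C/CCCCCCCC(=O)Nc1ccccc1C(C)C` gives 600 nM in this assay, and compound 3 `CCCCCCCC/C=C/CCCCCCCC(=O)Nc1ccc(OC)cc1OC` gives 3000 nM. Compound 3 stands at the highest of the three numbers; the steps of a 2.5-fold higher number from compound 1 to compound 3 (0.40 log units; beyond the scatter) and a 5.0-fold higher number from compound 2 to compound 3 (0.70 log units; beyond the scatter) both lie beyond the scatter. The remaining step, a 2.0-fold lower number from compound 1 to compound 2 (0.30 log units; within the scatter), lies within the scatter.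

Compound 4 `CCCCCCCC/C=C/CCCCCCCC(=O)Nc1cc(Cl)c(OC)cc1OC` is compound 3 with chloro in place of hydrogen on an aromatic carbon. Within the data shown here, no measured step adds a chloro group, so none bears directly on this change. Among the measured compounds shown here, the only step that adds a single group, a 2.0-fold lower number from compound 1 to compound 2 (0.30 log units; within the scatter), stayed within the scatter, and the two larger steps exchanged whole ring substituents rather than adding one. The expectation is therefore a step in this assay no larger than the scatter, a 1.5-fold lower number from compound 3 to compound 4 (0.18 log units; within the scatter), in either direction. Compound 4 is accordingly estimated at 2000 nM, with a range from 700 nM to 6000 nM.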

Compound 4, half-maximal inhibitory concentration: 520 nM
The estimate for compound 4 lay 3.8-fold (0.59 log units) above the measured number; the measured number lies below the stated range.
By their numbers in this assay, from the lowest: compounds 4, 2 and 1 (each within the scatter of the next, the first and the last beyond it); then compound 3.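

On this ring, a single added chlorine atom, a change of one heavy atom, is enough to move the number in this assay: the step is a 5.8-fold lower number from compound 3 to compound 4 (0.76 log units; beyond the scatter), and it lies beyond the scatter. Among these compounds, the only earlier step that added one group, the methyl group between the first two compounds, stayed within the scatter, so the carbon ortho to one methoxy group and para to the other is a place where a small addition can count. Nothing available explains how the chlorine produces this change.

As far as these compounds go, whether the gain belongs to chloro itself or to any small group on this carbon stays open, and a bromo or methyl group there would test that. Also open, from the compounds shown here alone, is whether chloro acts the same way without the two methoxy groups, as on the ring of compound 2.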